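Chloro for methyl on an allyl-protected phenol ketone

The source may report more compounds than this note shows. Statements on the series, on what has been measured and on what is new or still open speak of the compounds shown alone.

Measured compounds:
compound 1 `O=C(c1cccnc1)c1cc(Cl)ccc1O` gives 24800 nM.
compound 2 `C=CCOc1ccc(C)cc1C(=O)c1cccnc1` gives 98000 nM.
compound 3 `Cc1ccc(O)c(C(=O)c2cccnc2)c1` gives 10000 nM.

These three were read in a functional assay on PC-3 cells (Homo sapiens) for cytotoxicity, read by sulforhodamine B assay, with a stated time of 48 h; a higher number here means a weaker inhibitor, a lower number a stronger inhibitor. Compound 3 is the point from which the others branch. The difference between the cores of compound 2 and compound 3 is allyl in place of hydrogen on an oxygen on an aromatic ring, and that step, a 9.8-fold lower number from compound 2 to compound 3 (0.99 log units; beyond the scatter), is beyond the scatter. The other branch, (chloro in place of methyl on an aromatic carbon), gave the step of a 2.5-fold higher number from compound 3 to compound 1 (0.39 log units; beyond the scatter), also beyond the scatter. Compound 2 holds the highest number of the three, beyond the scatter from both others.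

Compound 4 `C=CCOc1ccc(Cl)cc1C(=O)c1cccnc1` has not yet been measured. Its relation to compound 2 is chloro in place of methyl on an aromatic carbon. In compound 4 the change sits para to an allyloxy group, while in compound 1 it sits para to a hydroxy group, so it is the same kind of change, not the same change, and it appears twice among the compounds here. Resting on the step from compound 3 to compound 1, compound 4 is expected to sit at a higher number than compound 2, with an expected step of a 2.2-fold higher number from compound 2 to compound 4 (0.35 log units; beyond the scatter). Because the number of compound 2 is already 98000 nM, compound 4 is expected to reach a higher number still. The estimate for compound 4 is 220000 nM, between 80000 nM and 600000 nM.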

Compound 4, half-maximal inhibitory concentration: > 100000 nM
Compound 4: a limit, no number (the forecaster's own chance of this, stated with the estimate: 35%); the middle value does not contradict the limit.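

In this assay compound 4 gives > 100000 nM, which is a limit of the assay and not a number. Chloro in place of methyl on the allyl-protected core can therefore be read only as a floor, an at least 1.0-fold higher number from compound 2 to compound 4 (0.00 log units; that floor lies within the scatter), so the result does not go against the step seen on the free phenol, but neither does it show that the step carries over in size or even that it is present on this core: the same change on two cores in this assay, a 2.5-fold higher number (0.39 log units; beyond the scatter) from compound 3 to compound 1 and an at least 1.0-fold higher number (0.00 log units; that floor lies within the scatter) from compound 2 to compound 4; the limit leaves it open whether they differ. The allyl change can be followed more firmly, as allyl in place of hydrogen on the oxygen gives an at least 4.0-fold higher number from compound 1 to compound 4 (0.60 log units; beyond the scatter), and it goes the same way on the methyl and chloro cores, though how closely the two sizes agree remains unsettled: the same change on two cores in this assay, a 9.8-fold lower number (0.99 log units; beyond the scatter) from compound 2 to compound 3 and an at least 4.0-fold lower number (0.60 log units; beyond the scatter) from compound 4 to compound 1; the limit leaves it open whether they differ.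

The compounds shown leave open how other groups in the place of methyl and chloro, such as methoxy or a nitrile, would read in this assay. They also leave open what a shorter or longer chain on the oxygen, or one ending in an amine or a carboxylic acid, would do in place of allyl.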